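The source may report more compounds than this note shows. Statements on the series, on what has been measured and on what is new or still open speak of the compounds shown alone.

In a functional assay on HT529 cells (Homo sapiens) for cytotoxicity (a lower number here means a stronger inhibitor, a higher number a weaker inhibitor), compound 1 `CCCCCCCCCCCCCC[C@H]1N[C@H](CO)[C@H]1O` gives 1.23 ug/mL, a measured number that offers a useful point of reference. Compound 2 `CC(C)CC[C@H](O)CCCCCCCCC[C@@H]1N[C@@H](CO)[C@@H]1O` stands at > 2 ug/mL, which is a limit of the assay and not a number. Going by these compounds, its exact position in this assay therefore remains open.

Compound 3 `CCCCCCCCCCCCCC[C@@H]1N[C@@H](CO)[C@@H]1O` differs from compound 2 in one place, with pentyl in place of 1-hydroxy-4-methylpentyl on a saturated chain carbon, nine bonds along the chain from a saturated ring carbon. Going by the values given here, no measured pair here isolates a change of this kind, so the expectation has to rest on the few values available. Among the compounds with values here, the only exact number is that of compound 1, at 1.23 ug/mL, which points to a modest shift rather than a large one. A small move towards a lower number is expected, with the estimated change being an at least 1.3-fold lower number from compound 2 to compound 3 (0.12 log units; that floor lies within the scatter). For compound 3 the estimated value is 1.5 ug/mL, with an expected range from 0.6 ug/mL to 4 ug/mL.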

Compound 3, half-maximal inhibitory concentration: 0.56 ug/mL
Compound 3: middle estimate off by 2.7-fold (0.43 log units), on the high side; the whole stated range lies above it.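

Putting pentyl in place of 1-hydroxy-4-methylpentyl, nine bonds along the chain from a saturated ring carbon, gives an at least 3.5-fold lower number from compound 2 to compound 3 (0.55 log units; beyond the scatter) in this assay. That size is only a floor, since compound 2 is known through a limit of the assay: the limit of > 2 ug/mL in this assay, at which 1 of the 3 values shown sits. Configuration alone also changes the result, with a 2.2-fold lower number from compound 1 to compound 3 (0.34 log units; beyond the scatter) as the mirror-image comparison: the fact that compounds 1 and 3 differ only in the configuration as drawn

The swap removes the hydroxy and the methyl of the chain together, so the compounds shown cannot separate what each contributes, and the true size of the step remains unknown. Going by these compounds, how a longer chain or an amine at this place would read in this assay also stays open, as does whether the preference between the two mirror-image forms would hold with the 1-hydroxy-4-methylpentyl group.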